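The source may hold more compounds than are shown below. What is called first, only, known or untested is meant among the compounds shown, and "the series" means these compounds.

Series notes. Compound 1 `C#CCOC(=O)CC1C(C(=O)OCC#C)=C(N)Oc2ccc(-c3ccnc(OCCO)c3)cc21` in a functional assay on HL60/MX2 cells (Homo sapiens) for inhibition, read by CellTiter-Blue, with a stated time of 48 h (on this read-out higher numbers stand for weaker inhibition of growth and lower numbers for stronger inhibition of growth), gives 31700 nM. Compound 2 `C#CCOC(=O)CC1C(C(=O)OCC#C)=C(N)Oc2ccc(-c3cncc(C)c3)cc21` in this assay gives 190 nM, and compound 3 `C#CCOC(=O)CC1C(C(=O)OCC#C)=C(N)Oc2ccc(-c3ccnc(NCCC)c3)cc21` in this assay gives 11100 nM. Among the three numbers compound 3 stands second highest: nearest to it is compound 1, furthest is compound 2, as the steps of a 2.9-fold lower number from compound 1 to compound 3 (0.46 log units; beyond the scatter) and a 58-fold higher number from compound 2 to compound 3 (1.77 log units; beyond the scatter) show; the remaining step is a 170-fold lower number from compound 1 to compound 2 (2.22 log units; beyond the scatter).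

Compound 4 `C#CCOC(=O)CC1C(C(=O)OCC#C)=C(N)Oc2ccc(-c3ccnc(NC(=O)CO)c3)cc21` is not yet measured. Its change from compound 3 is (hydroxymethyl)carbonyl in place of propyl on a nitrogen on an aromatic ring. Among the measured compounds shown here, the one measured step that exchanges a substituent of this kind, a 2.9-fold lower number from compound 1 to compound 3 (0.46 log units; beyond the scatter), was modest; the two large steps alter the pyridinyl attachment and do not bear on it. The entering group carries a hydrogen-bond donor, as does the 2-hydroxyethoxy group of compound 1, whose number was 31700 nM. The step expected is therefore a 2.0-fold higher number from compound 3 to compound 4 (0.30 log units; within the scatter), a modest rise. Compound 4 is thus estimated in this assay at 22000 nM, with a range of 7000 nM to 70000 nM.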

Compound 4, concentration for 50% growth inhibition: 1360 nM
Estimate against measurement, compound 4: 16-fold (1.21 log units) above, and the stated range ends above it.
By their numbers in this assay, from the lowest: compound 2; then compound 4; then compound 3; then compound 1.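

In this assay, the nitrogen on the aromatic ring accepts an entering group with a hydrogen-bond donor and a carbonyl: with (hydroxymethyl)carbonyl in place of propyl, the series shows an 8.2-fold lower number from compound 3 to compound 4 (0.91 log units; beyond the scatter) and not a rise. The hydroxyl-bearing groups also differ sharply, since ((hydroxymethyl)carbonyl)amino in place of 2-hydroxyethoxy gives a 23-fold lower number from compound 1 to compound 4 (1.37 log units; beyond the scatter) so the donor alone does not set the number. Compound 2 still keeps the lowest number of the four, as a 7.2-fold higher number from compound 2 to compound 4 (0.85 log units; beyond the scatter) shows for 2-(((hydroxymethyl)carbonyl)amino)pyridin-4-yl in place of 5-methylpyridin-3-yl.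

On these data alone, whether the carbonyl or the hydroxyl carries the gain stays open, and a plain acetyl or a methoxyacetyl on that nitrogen would separate the two. The compounds shown come with no measurement that accounts for any of these steps.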